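This account rests on a few compounds, and the source may have more. Where it says the series, first, only, none or still open, it means among the compounds named here.

Of the compounds shown here, three built on the same core have been measured in an ADME assay on Caco-2 cells (Homo sapiens) for permeability, in the apical to basolateral direction; on this read-out higher numbers stand for higher permeability and lower numbers for lower permeability. Compound 1 `CCC(=O)N1CCC(CN(C2Cc3cc(C#N)ccc3N(Cc3cncn3C)C2)S(=O)(=O)c2ccccn2)CC1` gives 0.5 10^-6 cm/s. Compound 2 `Cn1cncc1CN1CC(N(CC2CCN(C(=O)OC(C)(C)C)CC2)S(=O)(=O)c2ccccn2)Cc2cc(C#N)ccc21` gives 15.5 10^-6 cm/s. Compound 3 `Cn1cncc1CN1CC(N(CC2CCN(C(=O)NC(C)(C)C)CC2)S(=O)(=O)c2ccccn2)Cc2cc(C#N)ccc21` gives 0.6 10^-6 cm/s. Compound 3 therefore stands second highest of the three, close to compound 1 and far beneath compound 2.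

The steps among them are uneven. Changing the ethyl to tert-butoxy gave a 31-fold higher number from compound 1 to compound 2 (1.49 log units; beyond the scatter), whereas changing it to (tert-butyl)amino gave only a 1.2-fold higher number from compound 1 to compound 3 (0.08 log units; within the scatter). Between the two larger groups, a 26-fold lower number from compound 2 to compound 3 (1.41 log units; beyond the scatter).

Compound 4 `Cn1cncc1CN1CC(N(CC2CCN(C(=O)N3CCCCC3)CC2)S(=O)(=O)c2ccccn2)Cc2cc(C#N)ccc21` differs from compound 3 in one place: piperidin-1-yl in place of (tert-butyl)amino on a carbonyl carbon. For the measured compounds named here, no measured step covers this exact exchange. The group that leaves carries one hydrogen-bond donor and the group that enters carries none, a feature compound 4 shares with compound 2 and with compound 1, which sit at opposite ends of the range. Going by the values given here, the one large step from compound 3, seen with compound 2, went upward, so some rise is expected for compound 4, but the low number of compound 1 argues for caution. The expected step is a 5.0-fold higher number from compound 3 to compound 4 (0.70 log units; beyond the scatter). Compound 4 is estimated at 3 10^-6 cm/s, in a range from 0.5 10^-6 cm/s to 15 10^-6 cm/s.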

Compound 4, apparent permeability: 0.6 10^-6 cm/s
For compound 4 the middle estimate is 5.0-fold (0.70 log units) above the measured one; the range from low to high includes it.
By their numbers in this assay, from the lowest: compounds 1, 3 and 4 (each within the scatter of the next); then compound 2.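

In this assay, piperidin-1-yl in place of (tert-butyl)amino on this carbonyl carbon gives no change at the digits printed from compound 3 to compound 4 (within the scatter) even though the hydrogen-bond donor of the leaving group is gone, so removing that donor does not by itself bring the number up to that of compound 2. Among the four compounds the high number stays with tert-butoxy alone: piperidin-1-yl in its place gives a 26-fold lower number from compound 2 to compound 4 (1.41 log units; beyond the scatter) in this read-out, whereas piperidin-1-yl in place of ethyl gives a 1.2-fold higher number from compound 1 to compound 4 (0.08 log units; within the scatter) and leaves compounds 1, 3 and 4 together at the low end. No measurement shown here explains why tert-butoxy stands apart from the other three groups.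

Going by these compounds, it remains open whether the high number belongs to oxygen-linked groups on this carbonyl carbon in general, as methoxy or isopropoxy would show, or to tert-butoxy alone. On these data alone, it is also open whether a ring carrying a further hetero atom, such as morpholin-4-yl, or a small amine such as dimethylamino would stay with compounds 3 and 4.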